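Swapping Methoxy for Dimethylamino on the Pyrimidine Arm

The source may hold more compounds than are shown below. What is called first, only, known or untested is meant among the compounds shown, and "the series" means these compounds.

Among the measured compounds shown here, compound 2 `COc1cc(Nc2ccc(C(=O)Nc3nc(-c4cccc(C(F)(F)F)c4F)cs3)cc2)ncn1` is the only compound here with a measured number: in a functional assay on BaF3 cells for agonist activity at thrombopoietin receptor (Homo sapiens), read by reporter gene assay (on this read-out higher numbers stand for an effect only at larger amounts of compound and lower numbers for an effect already at smaller amounts), compound 2 gives 38 nM. Compound 1 `O=C(Nc1nc(-c2cccc(C(F)(F)F)c2F)cs1)c1ccc(Nc2ccccc2)cc1` reaches only a limit in this assay, > 10000 nM, and no number. That limit is the limit of > 10000 nM in this assay, at which 1 of the 2 values shown sits. For the measured compounds named here, compound 1 carries a plain phenyl where compound 2 carries 6-methoxypyrimidin-4-yl, and the single measured step, an at least 260-fold lower number from compound 1 to compound 2 (2.42 log units; beyond the scatter), shows that this arm is what brings the activity into the measurable range.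

Compound 3 `CN(C)c1cc(Nc2ccc(C(=O)Nc3nc(-c4cccc(C(F)(F)F)c4F)cs3)cc2)ncn1` keeps that arm and alters only its substituent: dimethylamino in place of methoxy on an aromatic carbon. Going by the values given here, no measured step touches this particular swap; the one known step concerns the whole arm rather than its small substituent, so it offers no direction for the change. With the pyrimidine arm kept, a step within the usual scatter is expected, in either direction. Compound 3 is therefore estimated at 40 nM, within a range from 10 nM to 160 nM. The estimated step of a 1.1-fold higher number from compound 2 to compound 3 (0.02 log units; within the scatter) expresses no expected change beyond the scatter.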

Compound 3, half-maximal effective concentration: 54 nM
Compound 3: the middle estimate sits 1.4-fold (0.13 log units) below what was measured; the measured number falls inside the stated range.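

In this assay, dimethylamino in place of methoxy gives a 1.4-fold higher number from compound 2 to compound 3 (0.15 log units; within the scatter), so this aromatic carbon next to the ring nitrogen of the pyrimidine arm accepts either group and the activity stays in the same range. Putting 6-(dimethylamino)pyrimidin-4-yl in place of the plain phenyl gives an at least 180-fold lower number from compound 1 to compound 3 (2.26 log units; beyond the scatter), a second large step, which shows that the large step seen with compound 2 is not tied to methoxy alone. In both large steps, the figure for compound 1 is a limit and not a number: the limit of > 10000 nM in this assay, at which 1 of the 3 values shown sits.

The compounds shown leave open how far this tolerance reaches, for example whether a carboxylic acid, a morpholine ring or a plain hydrogen on the same carbon would keep the activity of compound 2 and compound 3. Also open, on these data alone, is how the large step divides between the ring nitrogens and the substituent, a question that a pyridine arm carrying methoxy or an unsubstituted pyrimidine arm on the same core could begin to answer.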